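This account rests on a few compounds, and the source may have more. Where it says the series, first, only, none or still open, it means among the compounds named here.

Measured in a functional assay on A549 cells (Homo sapiens) for antiproliferative activity, read by MTT assay, with a stated time of 72 h; a lower number here means a stronger inhibitor, a higher number a weaker inhibitor:
- compound 1 `C/C=C/C(=O)Nc1cccc(Oc2nc(Nc3cccc(C#N)c3)nc3c2CSCC3)c1`: 17200 nM
- compound 2 `CCC/C=C/C(=O)Nc1cccc(Oc2nc(Nc3cccc(C#N)c3)nc3c2CSCC3)c1`: 5790 nM
- compound 3 `CC(C)=CC(=O)Nc1cccc(Oc2nc(Nc3cccc(C#N)c3)nc3c2CSCC3)c1`: 36900 nM

Compound 3 has the highest number of the three, at 36900 nM. It lies closest to compound 1, with a 2.1-fold higher number from compound 1 to compound 3 (0.33 log units; beyond the scatter), and furthest from compound 2, with a 6.4-fold higher number from compound 2 to compound 3 (0.80 log units; beyond the scatter).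

Compound 4 `CC(C)/C=C/C(=O)Nc1cccc(Oc2nc(Nc3cccc(C#N)c3)nc3c2CSCC3)c1` differs from compound 3 by 3-methylbut-1-en-1-yl in place of 2-methylprop-1-en-1-yl on a carbonyl carbon. Within the data shown here, no measured compound carries this group. The closest comparison is compound 2, with pent-1-en-1-yl on the same carbonyl carbon, and a 6.4-fold higher number from compound 2 to compound 3 (0.80 log units; beyond the scatter) sets the likely upper size of the change. The other relevant step is a 3.0-fold lower number from compound 1 to compound 2 (0.47 log units; beyond the scatter). Among the measured compounds shown here, compound 4 is therefore expected to fall nearer compound 2 than compound 3, though this rests on only three values. The expected change in this assay is a modest fall, estimated as a 4.1-fold lower number from compound 3 to compound 4 (0.61 log units; beyond the scatter). The estimated value for compound 4 is 9000 nM, with an expected range of 3500 nM to 25000 nM.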

Compound 4, half-maximal inhibitory concentration: 35900 nM
Compound 4: middle estimate off by 4.0-fold (0.60 log units), on the low side; measured number above the stated range.
By their numbers in this assay, from the lowest: compound 2; then compound 1; then compounds 4 and 3 (each within the scatter of the next).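

In this assay, 3-methylbut-1-en-1-yl and 2-methylprop-1-en-1-yl on the carbonyl carbon read alike (a 1.0-fold lower number from compound 3 to compound 4 (0.01 log units; within the scatter)), so the larger of these two branched groups brings no gain. Isopropyl in place of propyl on the double-bonded chain carbon gives a clear loss (a 6.2-fold higher number from compound 2 to compound 4 (0.79 log units; beyond the scatter)), and isopropyl in place of methyl also raises the number (a 2.1-fold higher number from compound 1 to compound 4 (0.32 log units; beyond the scatter)), so among these compounds a larger group lowers the number only in compound 2, with compound 3 and compound 4 going against that trend. No evidence on why the branched and straight chains differ is available here.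

Open, on these data alone, is whether a straight butyl or hexyl chain would extend the fall seen with propyl. Also open, as far as these compounds go, is how a terminal dimethylamino group on the chain would read.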